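Trading the Acid Chain for a Protected Pyrrolidine

The compounds below may be only part of what the source reports. "The series", "measured", "known", "first", "only" and "open" are said of these compounds alone.

Compound 1 `CN(C)c1ccc(C(=O)N2CCC(NS(=O)(=O)c3cc(S(=O)(=O)c4ccccc4)ccc3C(F)(F)F)CC2)cn1` gives 40 nM in an assay on isolated protein for displacement of a labelled ligand from secreted frizzled-related protein 1 (Homo sapiens), read by fluorescence polarization, with a stated time of 30 min; on this read-out higher numbers stand for weaker inhibition and lower numbers for stronger inhibition.
Compound 2 `O=C(O)CCCC(=O)N1CCC(NS(=O)(=O)c2cc(S(=O)(=O)c3ccccc3)ccc2C(F)(F)F)CC1` gives 500 nM in this assay.

Compound 2 stands at the higher of the two numbers, the weaker inhibitor. Within the data shown here, the single step recorded, a 13-fold higher number from compound 1 to compound 2 (1.10 log units; beyond the scatter), shows the cost of putting 3-carboxypropyl in place of 6-(dimethylamino)pyridin-3-yl. Compound 3 `CC(C)(C)OC(=O)N1CC[C@H](C(=O)N2CCC(NS(=O)(=O)c3cc(S(=O)(=O)c4ccccc4)ccc3C(F)(F)F)CC2)C1` is not yet measured; it differs from compound 2 in one place: 1-(tert-butoxycarbonyl)pyrrolidin-3-yl in place of 3-carboxypropyl on a carbonyl carbon. Among the measured compounds shown here, no step pairs these two groups directly, so only the large step from compound 1 to compound 2 bears on it, because compound 2 holds 500 nM while the acid-free compound 1 holds 40 nM. Compound 3, also acid-free, is expected to recover part of that loss, an estimated 150 nM within 40 nM to 600 nM. This estimate means a step of a 3.3-fold lower number from compound 2 to compound 3 (0.52 log units; beyond the scatter).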

Compound 3, half-maximal inhibitory concentration: 70 nM
For compound 3 the middle estimate is 2.1-fold (0.33 log units) above the measured one, and the stated range covers the measured number.
By their numbers in this assay, from the lowest: compounds 1 and 3 (each within the scatter of the next); then compound 2.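

In this assay, the step to 1-(tert-butoxycarbonyl)pyrrolidin-3-yl at this position on the carbonyl carbon gives a 7.1-fold lower number from compound 2 to compound 3 (0.85 log units; beyond the scatter). Set against 6-(dimethylamino)pyridin-3-yl, the same group gives a 1.8-fold higher number from compound 1 to compound 3 (0.24 log units; within the scatter), so in these two examples a five-membered non-aromatic ring does as well as the aromatic one. No measurement here explains either result.

Still open, on these data alone, is how much of this depends on the tert-butoxycarbonyl group, which the same pyrrolidine with a free ring amine would test. As far as these compounds go, the opposite stereocentre is also open.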